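From Imidazolyl to Phenylsulfanyl: Expected Shift in Cytotoxicity

The source may report more compounds than this note shows. Statements on the series, on what has been measured and on what is new or still open speak of the compounds shown alone.

Among the compounds with values here, compound 2 `Cc1nn(C)c(-n2ccnc2)c1/C=N/OCc1ccc(C(=O)OC(C)(C)C)cc1` has the highest number of the two measured so far: in a functional assay on XF498 cells (Homo sapiens) for cytotoxicity (a lower number here means a stronger inhibitor, a higher number a weaker inhibitor), compound 2 gives 8.15 ug/mL, while compound 1 `Cc1nn(C)c(N2CCCC2)c1/C=N/OCc1ccc(C(=O)OC(C)(C)C)cc1` gives 0.12 ug/mL. Within the data shown here, the only measured step, a 68-fold higher number from compound 1 to compound 2 (1.83 log units; beyond the scatter), shows that exchanging the group on this aromatic carbon can move the number a great deal. Compound 3 `Cc1nn(C)c(Sc2ccccc2)c1/C=N/OCc1ccc(C(=O)OC(C)(C)C)cc1` carries the next exchange, (phenylsulfanyl in place of 1H-imidazol-1-yl on an aromatic carbon). Among the measured compounds shown here, no measured step covers a phenylsulfanyl group, so the direction rests on that single comparison; because a 68-fold higher number from compound 1 to compound 2 (1.83 log units; beyond the scatter) was large, a sizeable move is expected, most likely back toward lower numbers, giving a 6.8-fold lower number from compound 2 to compound 3 (0.83 log units; beyond the scatter). Compound 3 is therefore estimated at 1.2 ug/mL, within 0.15 ug/mL to 10 ug/mL.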

Compound 3, half-maximal inhibitory concentration: 0.28 ug/mL
For compound 3 the middle estimate is 4.3-fold (0.63 log units) above the measured one; low and high end bracket the measured number.
By their numbers in this assay, from the lowest: compound 1; then compound 3; then compound 2.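

Putting phenylsulfanyl in place of 1H-imidazol-1-yl gives a 29-fold lower number from compound 2 to compound 3 (1.46 log units; beyond the scatter) in this assay, so the high number of compound 2 is not shared by every aromatic ring at this carbon. Phenylsulfanyl in place of pyrrolidin-1-yl gives only a 2.3-fold higher number from compound 1 to compound 3 (0.37 log units; beyond the scatter), which shows that a low number here does not require a nitrogen joining the group to the core. Nothing available explains these differences.

From the compounds shown here alone, open-chain groups at this carbon, such as dimethylamino or methylsulfanyl, remain open, as does the effect of a chlorine on the phenyl ring of phenylsulfanyl.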